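The compounds below may be only part of what the source reports. "The series", "measured", "known", "first", "only" and "open" are said of these compounds alone.

Working notes on the series.

Compound 1, `O=C(Nc1ccc(OC(=O)c2ccc(Cl)cc2)cc1)Nc1ccc(Cl)c(C(F)(F)F)c1`, is the reference point. In a functional assay on HT-29 cells (Homo sapiens) for antiproliferative activity, read by MTT assay, with a stated time of 48 h (on this read-out higher numbers stand for weaker inhibition and lower numbers for stronger inhibition), compound 1 gives 8320 nM. Compound 2, `O=C(Nc1ccccc1)Nc1ccc(OC(=O)c2ccc([N+](=O)[O-])cc2)cc1`, carries a nitro on its benzoate ring and a plain phenylurea; in this assay compound 2 gives 185000 nM. For the measured compounds named here, of the two numbers measured so far, the number of compound 2 is the higher one, and the gap to compound 1 is beyond the usual scatter, so compound 2 is the weaker of the two measured compounds on this read-out.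

Compound 3, `COc1ccc(C(=O)Oc2ccc(NC(=O)Nc3ccccc3)cc2)cc1`, is not yet measured. It differs from compound 2 by methoxy in place of nitro on an aromatic carbon. Going by the values given here, no measured pair shows this exchange, so there is no step to lean on. The expectation is a small shift, probably toward a lower number, with a size that may not rise above the scatter; the step from compound 2 to compound 3 is expected to be a 1.7-fold lower number from compound 2 to compound 3 (0.23 log units; within the scatter). On this basis compound 3 is estimated to give 110000 nM in this assay, with a range from 25000 nM to 400000 nM.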

Compound 3, half-maximal inhibitory concentration: 175000 nM
Estimate against measurement, compound 3: 1.6-fold (0.20 log units) below; the measured number falls inside the stated range.
By their numbers in this assay, from the lowest: compound 1; then compounds 3 and 2 (each within the scatter of the next).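

The series now has its first step between compounds that differ in one place: in this assay, methoxy in place of nitro on an aromatic carbon, para to a large group, gives a 1.1-fold lower number from compound 2 to compound 3 (0.02 log units; within the scatter) and so separates the two compounds by no more than the usual scatter. For the compounds shown here, with the plain phenylurea held constant, the change from 4-nitrophenyl to 4-methoxyphenyl therefore leaves the read-out indistinguishable, which the single unpaired comparison of compound 1 and compound 2 could not show. The step comes with no measured property of either group, and nothing here accounts for it.

Going by these compounds alone, open is whether this position stays as indifferent with a group of another kind, such as an amine or a carboxylic acid, since nitro and methoxy are the only two groups seen here on the phenylurea background. Also open, going by these compounds, is whether the same exchange would read alike on the chloro- and trifluoromethyl-substituted urea of compound 1, which differs from compound 2 and compound 3 in more than one place and so cannot yet assign its number to any single part of the structure.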